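Sulfonyl substituent variation in the acylsulfonamide series

A few compounds are considered here, and "the series" means these few. Any claim that something is new, unique, unknown or untested is made for them only; others in the source may bear on it.

Measured so far:
compound 1 `CC(C)(C)OC(=O)NCCS(=O)(=O)NC(=O)c1ccc(Nc2nc(NC3(c4ccc(Cl)cc4)CC3)nc(OCC(F)(F)F)n2)cc1` gives 93%
compound 2 `CNC(=O)NCCS(=O)(=O)NC(=O)c1ccc(Nc2nc(NC3(c4ccc(Cl)cc4)CC3)nc(OCC(F)(F)F)n2)cc1` gives 100%
compound 3 `O=C(NS(=O)(=O)c1ccc(F)cc1)c1ccc(Nc2nc(NC3(c4ccc(Cl)cc4)CC3)nc(OCC(F)(F)F)n2)cc1` gives 99%

In an ADME assay on microsomes from liver (Rattus norvegicus) for metabolic stability, with a stated time of 10 min (on this read-out higher numbers stand for a more stable compound and lower numbers for a less stable compound), compound 1 sits within the usual scatter of both other compounds. The step of a number 7 percentage points higher from compound 1 to compound 2 (within the scatter) replaces tert-butoxy with methylamino on a carbonyl carbon; the step of a number 6 percentage points higher from compound 1 to compound 3 (within the scatter) replaces the whole 2-((tert-butoxycarbonyl)amino)ethyl chain on the sulfonyl sulfur with 4-fluorophenyl; and the step of a number 1 percentage points lower from compound 2 to compound 3 (within the scatter) does the same from the methylcarbamoyl analogue. None of the three exchanges at the sulfonyl side moves the read-out beyond the scatter.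

Compound 4 `CS(=O)(=O)NC(=O)c1ccc(Nc2nc(NC3(c4ccc(Cl)cc4)CC3)nc(OCC(F)(F)F)n2)cc1` differs from compound 1 thus: hydrogen in place of ((tert-butoxycarbonyl)amino)methyl on a saturated chain carbon bound to a sulfonyl sulfur. The change cuts the substituent on the sulfonyl sulfur back to methyl, as the difference read one bond further out shows. The most relevant precedent is the step from compound 1 to compound 3, which also removed the 2-((tert-butoxycarbonyl)amino)ethyl chain and stayed within the scatter, as did the step from compound 2 to compound 3. Nothing measured here points to a shift in either direction, so the expected step is a number 2 percentage points higher from compound 1 to compound 4 (within the scatter), within the scatter. Compound 4 is therefore estimated at 95% (range 85% to 100%).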

Compound 4, percent of the compound remaining: 85%
The estimate for compound 4 lay 10 percentage points above the measured number; the range from low to high includes it.
By their numbers in this assay, from the lowest: compounds 4, 1, 3 and 2 (each within the scatter of the next, the first and the last beyond it).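

Methyl on the sulfonyl sulfur shows that this position is not flat in this assay, as the three earlier compounds alone suggested: the exchange gives a number 14 percentage points lower from compound 3 to compound 4 (beyond the scatter) and a number 15 percentage points lower from compound 2 to compound 4 (beyond the scatter), yet a number 8 percentage points lower from compound 1 to compound 4 (within the scatter). The 4-fluorophenyl and 2-((methylcarbamoyl)amino)ethyl compounds therefore separate from the methyl compound, while the 2-((tert-butoxycarbonyl)amino)ethyl compound separates from neither end of the set. No measurement at hand accounts for this separation.

Going by these compounds, it remains open whether an ethyl group or a longer plain alkyl chain on the sulfonyl sulfur would group with methyl or with the larger substituents. A terminal primary amine or carboxylic acid on the ethyl chain, or an unsubstituted phenyl ring, would test the same question.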